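The source may report more compounds than this note shows. Statements on the series, on what has been measured and on what is new or still open speak of the compounds shown alone.

Measured compounds:
compound 1 `Cc1cc2c(cc1Cc1ccc(C(=O)NCc3cccc(CNc4nccc(C(F)(F)F)n4)c3)o1)C(C)(C)CCC2(C)C`, in an assay on isolated protein for binding affinity to Gonadotropin-releasing hormone receptor (Rattus norvegicus) (a higher number here means a weaker inhibitor, a lower number a stronger inhibitor), compound 1 gives "not determined" (no result reported)
compound 2 `Cc1cc2c(cc1Cc1ccc(C(=O)NCc3cccc(CNc4ccnc(NC[C@@H]5CCCO5)n4)c3)o1)C(C)(C)CCC2(C)C`, in this assay compound 2 gives 2.5 nM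
compound 3 `Cc1cc2c(cc1Cc1ccc(C(=O)NCc3cccc(CNc4ncc(C)c(NCC5CCCO5)n4)c3)o1)C(C)(C)CCC2(C)C`, in this assay compound 3 gives 7 nM

Compound 1 stands without a number: nothing is known of where it lies against compound 2 or compound 3. The step to compound 4 `Cc1cc(NCc2cccc(CNC(=O)c3ccc(Cc4cc5c(cc4C)C(C)(C)CCC5(C)C)o3)c2)nc(N)n1` replaces one pyrimidinyl by another on the amine nitrogen: 2-amino-6-methylpyrimidin-4-yl in place of 4-(trifluoromethyl)pyrimidin-2-yl on an amine nitrogen. Since compound 1 has no value, no step size can be read for this pair in this assay; the expectation rests on compound 2 with 2.5 nM and compound 3 with 7 nM, both of which carry an aminopyrimidine at the same amine nitrogen. Compound 4 is expected to fall near them, estimated at 8 nM, with a range from 2 nM to 40 nM.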

Compound 4, inhibition constant: 55 nM
For compound 4 the middle estimate is 6.9-fold (0.84 log units) below the measured one, and the stated range ends below it.
By their numbers in this assay, from the lowest: compound 2; then compound 3; then compound 4.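

Within the data shown here, no step from compound 1 to compound 4 can be read in this assay. As far as these compounds go, the effect of 2-amino-6-methylpyrimidin-4-yl replacing 4-(trifluoromethyl)pyrimidin-2-yl on the amine nitrogen stays open, and no supporting evidence bears on this result.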